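The source may report more compounds than this note shows. Statements on the series, on what has been measured and on what is new or still open speak of the compounds shown alone.

In an ADME assay on Vero cells (Chlorocebus sabaeus) for cytotoxicity, read by CellTiter-Glo, with a stated time of 72 h (on this read-out lower numbers stand for higher toxicity in this test and higher numbers for lower toxicity in this test), compound 1 (`CCNc1n[n+]([O-])c2cc(Cl)ccc2[n+]1[O-]`) gives 2.6 ug/mL and sits at the upper end of the three numbers in hand. Compound 2 (`[O-][n+]1nc(NC2CCC2)[n+]([O-])c2ccc(Cl)cc21`) gives 1.6 ug/mL and compound 3 (`[O-][n+]1nc(N[C@@H]2C[C@H]3CC[C@@H]2C3)[n+]([O-])c2ccc(Cl)cc21`) gives 1.1 ug/mL on the same read-out. The upper position of compound 1 is only partly secure: the step of a 1.6-fold lower number from compound 1 to compound 2 (0.21 log units; within the scatter) stays within the scatter, the step of a 2.4-fold lower number from compound 1 to compound 3 (0.37 log units; beyond the scatter) goes beyond it, and the step of a 1.5-fold lower number from compound 2 to compound 3 (0.16 log units; within the scatter) stays within it.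

Compound 4 (`CCNc1n[n+]([O-])c2cc(OC)ccc2[n+]1[O-]`) keeps the ethyl group on the nitrogen of compound 1 and carries methoxy in place of chloro on an aromatic carbon of the six-membered aromatic ring, meta to a fused ring and para to a fused ring. All three measured steps change the group on the nitrogen and leave the chloro untouched, so none measures this change directly and the data give it no size. They serve only as a loose yardstick for the series, the largest being the modest step from compound 1 to compound 3 shown above. No step beyond the scatter is therefore expected in this assay in either direction, though this rests on thin evidence. The expected change is a 1.2-fold higher number from compound 1 to compound 4 (0.06 log units; within the scatter) as a working estimate. For compound 4 the estimated value is 3 ug/mL with an expected range of 1.2 ug/mL to 7.5 ug/mL on this read-out.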

Compound 4, half-maximal cytotoxic concentration: 16 ug/mL
Compound 4: middle estimate off by 5.3-fold (0.73 log units), on the low side; measured number above the stated range.
By their numbers in this assay, from the lowest: compounds 3, 2 and 1 (each within the scatter of the next, the first and the last beyond it); then compound 4.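

Placing methoxy in place of chloro on the aromatic carbon, meta to a fused ring and para to a fused ring, while keeping the ethyl group on the nitrogen, gives a 6.2-fold higher number from compound 1 to compound 4 (0.79 log units; beyond the scatter) in this assay; this is the first direct reading at this position and the only upward step in the series so far. It also exceeds a 2.4-fold lower number from compound 1 to compound 3 (0.37 log units; beyond the scatter), the largest of the steps that change the group on the nitrogen, so among the compounds shown, this single change on the aromatic carbon moves the number further than any change on the nitrogen. No measurement in hand accounts for the rise.

As far as these compounds go, this position rests on one pair, so whether methoxy gives a similar rise alongside the groups on the nitrogen of compound 2 and compound 3 remains open. Also open, from the compounds shown here alone, is whether the rise follows from methoxy entering or chloro leaving, a question that fluoro, ethoxy or an amine on the same aromatic carbon would bear on.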